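From compound 2 to compound 3: a larger selenium group

The source may report more compounds than this note shows. Statements on the series, on what has been measured and on what is new or still open speak of the compounds shown alone.

In a functional assay on HepG2 cells (Homo sapiens) for antiproliferative activity, read by MTT assay, with a stated time of 48 h (a higher number here means a weaker inhibitor, a lower number a stronger inhibitor), compound 1 `COc1ccc(N(C)c2ccnc(Cl)n2)cc1O` gives 464 nM, and compound 2 `COc1ccc(N(C)c2ccnc(Cl)n2)cc1OCC[Se]C#N` gives 1670 nM, the higher of the two numbers. Compound 3 `COc1ccc(N(C)c2ccnc(Cl)n2)cc1OCCCC[Se]C#N` differs from compound 2 by a group of 5 heavy atoms (3 carbon, 1 nitrogen, 1 selenium; no ring) in place of a group of 3 heavy atoms (1 carbon, 1 nitrogen, 1 selenium; no ring), on a saturated chain carbon, two bonds along the chain from an oxygen on an aromatic ring. Within the data shown here, only one measured step bears on this change: a 3.6-fold higher number from compound 1 to compound 2 (0.56 log units; beyond the scatter), with the selenium group placed on an oxygen on an aromatic ring. That step is a different change and modest in size, so no shift beyond the scatter is expected. The expected step is a 1.2-fold lower number from compound 2 to compound 3 (0.08 log units; within the scatter). For compound 3, the estimate is 1400 nM, with an expected range from 550 nM to 3500 nM.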

Compound 3, half-maximal inhibitory concentration: > 10000 nM
Compound 3: no number, only a limit (the forecaster's own chance of this, stated with the estimate: 3%); at least 7.1-fold (0.85 log units) between middle value and limit.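

In this assay, the chain carrying the selenium group proves sensitive to length at this position, which compound 2 alone could not show: the group of 5 heavy atoms in place of the group of 3 heavy atoms gives an at least 5.9-fold higher number from compound 2 to compound 3 (0.77 log units; beyond the scatter), and the full group on the oxygen gives an at least 21-fold higher number from compound 1 to compound 3 (1.33 log units; beyond the scatter). For compound 3 the result is a limit, not a number: the limit of > 10000 nM in this assay, at which 1 of the 3 values shown sits.

As far as these compounds go, how far compound 3 lies past that limit stays open. So does whether an amine or a carboxylic acid at the end of this chain, in place of the selenium group, would behave as compound 2 does.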